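The source may report more compounds than this note shows. Statements on the series, on what has been measured and on what is new or still open speak of the compounds shown alone.

Measured compounds:
compound 1 `COc1ccc(NC(=O)C(=O)c2cn(CC(C)C)c3ccccc23)cn1` — 317 nM in a functional assay on FaDu cells (Homo sapiens) for cytotoxicity, read by MTT assay, with a stated time of 72 h; on this read-out lower numbers stand for higher toxicity in this test and higher numbers for lower toxicity in this test
compound 2 `COc1ccc(NC(=O)C(=O)c2cc(C(C)C)n3ccccc23)cn1` — 160 nM in this assay

Going by the values given here, of the two numbers known in this assay, compound 1 stands with the higher one, and its nearest neighbour is compound 2, whose number is within the usual scatter of that of compound 1. Among the compounds with values here, the two values therefore show no difference that can be read as a real one, and no step between these two compounds is recorded.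

The account now turns to compound 3 `COc1ccc(NC(=O)C(=O)c2cn(CC3CCO3)c3ccccc23)cn1`, which has yet to be measured in this assay. It differs from compound 1 in one place: oxetan-2-yl in place of isopropyl on a saturated chain carbon bound to an aromatic nitrogen. The exchange keeps the saturated chain carbon bound to an aromatic nitrogen and only swaps the group on it, isopropyl for oxetan-2-yl.

Within the data shown here, with no recorded step to lean on, the expected step from compound 1 to compound 3 is a 1.1-fold higher number from compound 1 to compound 3 (0.04 log units; within the scatter), that is, none beyond the scatter. Compound 3 is accordingly estimated at 350 nM, with a range from 120 nM to 1000 nM.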

Compound 3, concentration lethal to 50% of the cells: 686 nM
Compound 3: middle estimate off by 2.0-fold (0.29 log units), on the low side; low and high end bracket the measured number.
By their numbers in this assay, from the lowest: compounds 2 and 1 (each within the scatter of the next); then compound 3.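

In this assay, going by these compounds alone, oxetan-2-yl in place of isopropyl on a saturated chain carbon bound to an aromatic nitrogen gives a 2.2-fold higher number from compound 1 to compound 3 (0.34 log units; beyond the scatter), which stands for lower toxicity in this test and is the only step on record here. It shows that the group at this place can move the read-out beyond the scatter, though the step is modest and rests on a single pair of compounds. No supporting measurement is available to explain this step.

The compounds shown leave open whether the ring oxygen or the ring itself goes with the step, a question that cyclobutyl at the same place would address. They also leave open how an amine such as azetidin-3-yl, or a longer chain, would read there.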